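Chain extension at the ether-linked ester branch of compound 1

The source may hold more compounds than are shown below. What is called first, only, known or untested is meant among the compounds shown, and "the series" means these compounds.

Measured so far:
compound 1 `CCCCC(Oc1ccc2c(=O)c(-c3ccc(O)cc3)coc2c1)C(=O)OCC` — 4500 nM
compound 2 `O=c1c(-c2ccc(O)cc2)coc2cc(OCCCCCCO)ccc12` — 120 nM
compound 3 `CCOc1ccc2c(=O)c(-c3ccc(O)cc3)coc2c1` — 80 nM

In an assay (Cricetulus griseus) for inhibition of aldehyde dehydrogenase, mitochondrial (Homo sapiens) (a higher number here means a weaker inhibitor, a lower number a stronger inhibitor), compound 1 gives the highest number of the three measured compounds; compound 2 and compound 3 both lie far lower, beyond the scatter. Compound 4 `CCCCCCC(Oc1ccc2c(=O)c(-c3ccc(O)cc3)coc2c1)C(=O)OCC` is not yet measured. It differs from compound 1 in one place: ethyl in place of hydrogen on a saturated chain carbon, five bonds along the chain from a carbonyl carbon and an oxygen on an aromatic ring.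

Among the measured compounds shown here, the only measured step that touches the ether side chain is a 1.5-fold lower number from compound 2 to compound 3 (0.18 log units; within the scatter); cutting away a whole hydroxybutyl chain there left the number essentially where it was. Nothing measured shows what lengthening an alkyl chain on the carbon that also carries the ester does, and the gap from compound 1 to compound 2 or compound 3 involves the ester branch as a whole, not chain length. On that basis no step beyond the scatter is expected in this assay from the added ethyl, with the number staying in the region of compound 1.

Compound 4 is therefore expected to give about 4000 nM in this assay, in the range 1500 nM to 12000 nM, an estimated step of a 1.1-fold lower number from compound 1 to compound 4 (0.05 log units; within the scatter).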

Compound 4, half-maximal inhibitory concentration: 7200 nM
Estimate against measurement, compound 4: 1.8-fold (0.26 log units) below; measured number inside the range.
By their numbers in this assay, from the lowest: compounds 3 and 2 (each within the scatter of the next); then compounds 1 and 4 (each within the scatter of the next).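

In this assay, ethyl in place of hydrogen on a saturated chain carbon, five bonds along the chain from a carbonyl carbon and an oxygen on an aromatic ring, gives a 1.6-fold higher number from compound 1 to compound 4 (0.20 log units; within the scatter), so this change leaves no readable shift in the number. Among the compounds shown here, this is the first reading of a chain change at this position; the only earlier step on an ether side chain, a 1.5-fold lower number from compound 2 to compound 3 (0.18 log units; within the scatter), was made at a different place and in a series without the ester, so it could not speak for this one. No measurement is at hand that bears on why the added ethyl leaves the number unmoved.

The compounds shown leave open whether a longer chain, a phenyl ring or an amine in place of the ethyl would carry the number beyond the scatter, or whether this position stays flat for such groups as well. They also leave open which part of the ester branch separates compound 1 and compound 4 from the lower numbers of compound 2 and compound 3, and a carboxylic acid in place of the ethyl ester would be one direct probe of that.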